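The source may report more compounds than this note shows. Statements on the series, on what has been measured and on what is new or still open speak of the compounds shown alone.

In an ADME assay on HepG2 cells (Homo sapiens) for cytotoxicity, read by fluorescence and resazurin assay, with a stated time of 24 h (a lower number here means that less compound is tolerated, a higher number that more compound is tolerated), compound 1 `O=S1(=O)C=C(Sc2nnc(-c3cccnc3)o2)c2ccccc21` gives 14000 nM. Its only measured companion, compound 2 `COC(=O)c1ccc(-c2nnc(SC3=CS(=O)(=O)c4ccccc43)o2)cc1`, gives 18000 nM in this assay, and the two numbers lie within the usual scatter of each other, so compound 1 cannot be set apart from compound 2 on this read-out. Compound 3 `Cc1ccc(-c2nnc(SC3=CS(=O)(=O)c4ccccc43)o2)cc1` has not yet been measured. It differs from compound 1 in a single place: 4-methylphenyl in place of pyridin-3-yl on an aromatic carbon. For the measured compounds named here, no step between two measured compounds has been recorded for this series, so the weight of this change must be judged from the two numbers alone. Because compound 2, which carries a carbon-only aromatic ring on the shared core, gives 18000 nM close to compound 1, the step of a 1.1-fold higher number from compound 1 to compound 3 (0.03 log units; within the scatter) is expected to stay within the scatter, with no clear direction. Compound 3 is therefore estimated at 15000 nM, with a range from 7000 nM to 32000 nM.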

Compound 3, half-maximal cytotoxic concentration: 31000 nM
Compound 3: the middle estimate sits 2.1-fold (0.32 log units) below what was measured, within the range that was stated.
By their numbers in this assay, from the lowest: compounds 1, 2 and 3 (each within the scatter of the next, the first and the last beyond it).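

In this assay, the group on this aromatic carbon of the shared core gives its first step beyond the scatter: a 2.2-fold higher number from compound 1 to compound 3 (0.35 log units; beyond the scatter), modest in size, with 4-methylphenyl in place of pyridin-3-yl. The group at the far end of the carbon-only ring gives no such separation, as methyl in place of methoxycarbonyl gives a 1.7-fold higher number from compound 2 to compound 3 (0.24 log units; within the scatter). Nothing measured here explains either step.

The two parts of the first change, the loss of the ring nitrogen and the gain of the methyl, remain unseparated, and a plain phenyl on this carbon would be needed to tell them apart. Also open, as far as these compounds go, is what an amine or a carboxylic acid would give in place of the methyl on that ring.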